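A few compounds are considered here, and "the series" means these few. Any claim that something is new, unique, unknown or untested is made for them only; others in the source may bear on it.

In a functional assay on ileum (Cavia porcellus) for inhibition (on this read-out higher numbers stand for weaker inhibition and lower numbers for stronger inhibition), compound 2 `COC(=O)C1=C(C)NC(C)=C(C(=O)OC)C1c1c(-c2ccccn2)nc2sccn12` gives 2570 nM and compound 1 `COC(=O)C1=C(C)NC(C)=C(C(=O)OC)C1c1c(-c2c(Cl)csc2Cl)nc2sc(C)cn12` gives 3230 nM, two numbers within the scatter of each other, while compound 3 `COC(=O)C1=C(C)NC(C)=C(C(=O)OC)C1c1c(-c2cccs2)nc2sccn12` lies well lower at 110 nM. Compound 4 `COC(=O)C1=C(C)NC(C)=C(C(=O)OC)C1c1c(-c2ccccn2)nc2sc(C)cn12` differs from compound 2 by methyl in place of hydrogen on an aromatic carbon. Among the compounds with values here, the only measured step, a 23-fold lower number from compound 2 to compound 3 (1.37 log units; beyond the scatter), is large but concerns thiophen-2-yl in place of pyridin-2-yl, so it does not size this change. Compound 1 carries the same methyl with another aromatic group and gives 3230 nM. In this assay, no step beyond the scatter is therefore expected, the estimated change being a 1.1-fold higher number from compound 2 to compound 4 (0.04 log units; within the scatter). For compound 4 the estimated value is 2800 nM, with an expected range of 900 nM to 8000 nM.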

Compound 4, half-maximal inhibitory concentration: 2810 nM
Beside the measured number, compound 4's estimate is 1.0-fold (0.00 log units) below it; measured number inside the range.
By their numbers in this assay, from the lowest: compound 3; then compounds 2, 4 and 1 (each within the scatter of the next).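

In this assay, methyl in place of hydrogen on the aromatic carbon next to the ring sulfur gives a 1.1-fold higher number from compound 2 to compound 4 (0.04 log units; within the scatter) with pyridin-2-yl on the core, so this position takes the methyl with no change beyond the scatter. With the methyl kept, exchanging the aromatic group gives a 1.1-fold lower number from compound 1 to compound 4 (0.06 log units; within the scatter) and does not separate these two groups on this read-out. No evidence on the reason for either result is at hand. As far as these compounds go, whether methyl behaves alike alongside thiophen-2-yl remains open, as does the outcome with an ethyl group, an amine or a carboxylic acid on this carbon.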